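A few compounds are considered here, and "the series" means these few. Any claim that something is new, unique, unknown or untested is made for them only; others in the source may bear on it.

Compound 2, `Cc1ccc2c(c1)C(=O)N(c1ccc(-c3ccccc3)cc1)C2=O`, stands in a functional assay on HONE1 cells (Homo sapiens) for cytotoxicity, read by MTT assay, with a stated time of 24 h (on this read-out higher numbers stand for weaker inhibition and lower numbers for stronger inhibition), only at a limit: compound 2 gives > 200000 nM, which is a limit of the assay and not a number. Compound 1, `O=C1c2ccccc2C(=O)N1c1ccc(-c2ccccc2)cc1`, rests at the same place; in this assay compound 1 gives > 200000 nM, again a limit. The step that the two limits leave unreadable from compound 1 to compound 2 therefore cannot be read, and the limit of > 200000 nM in this assay, at which 2 of the 2 values shown sit, holds both values shown. Compound 3, `Cc1ccc2c(c1)C(=O)N(c1ccc(/N=N\c3ccccc3)cc1)C2=O`, differs from compound 2 in one place: a group of 8 heavy atoms (6 carbon, 2 nitrogen; one six-membered aromatic ring of carbon only) in place of a group of 6 heavy atoms (6 carbon; one six-membered aromatic ring of carbon only), on an aromatic carbon. Within the data shown here, no measured step touches this change, and the single recorded step is itself unreadable. Nothing in the series argues for movement beyond the scatter in this assay, so the expected step from compound 2 to compound 3 is small, an at least 1.3-fold lower number from compound 2 to compound 3 (0.12 log units; that floor lies within the scatter), and the result may again come back only as a limit. Compound 3 is expected to give about 150000 nM in this assay, within a range from 30000 nM to 500000 nM.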

Compound 3, half-maximal inhibitory concentration: > 200000 nM
Compound 3 ended at the assay's limit; the forecaster's own chance of this, stated with the estimate: 60%; at least 1.3-fold (0.12 log units) between middle value and limit.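

No step can be read from compound 2 to compound 3, since each rests at a limit and not at a number: the limit of > 200000 nM in this assay, at which 3 of the 3 values shown sit. The compounds shown leave open how far each lies past that limit, and whether any change to the shared core moves the read-out.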